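From 2-fluorophenyl to 4-nitrophenyl, without a starting number

The compounds below may be only part of what the source reports. "The series", "measured", "known", "first", "only" and "open" are said of these compounds alone.

In a functional assay on HCT-116 cells (Homo sapiens) for antiproliferative activity, read by MTT assay, with a stated time of 72 h (on this read-out higher numbers stand for weaker inhibition and lower numbers for stronger inhibition), compound 1 (`Nc1nc(N)c2cc(CSC(=S)N3CCN(c4ccccc4)CC3)ccc2n1`) gives 4120 nM and compound 2 (`Nc1nc(N)c2cc(CSC(=S)N3CCN(c4ccc(O)cc4)CC3)ccc2n1`) gives 5980 nM as its value. Going by the values given here, compound 3 (`Nc1nc(N)c2cc(CSC(=S)N3CCN(c4ccccc4F)CC3)ccc2n1`) has no single number and reads "not determined" (no result reported) in this assay so no step can start from it. Compound 4 (`Nc1nc(N)c2cc(CSC(=S)N3CCN(c4ccc([N+](=O)[O-])cc4)CC3)ccc2n1`) has 4-nitrophenyl in place of 2-fluorophenyl on an amine nitrogen in a ring. Among the compounds with values here, the only measured step, a different change, shows a 1.5-fold higher number from compound 1 to compound 2 (0.16 log units; within the scatter) for hydroxy in place of hydrogen on an aromatic carbon. Resting on that one step, compound 4 is expected in this assay to sit near compound 1 and compound 2, with no step beyond the scatter. For compound 4 the estimated value is 5000 nM with an expected range from 1800 nM to 14000 nM once measured.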

Compound 4, half-maximal inhibitory concentration: 4680 nM
Compound 4: middle estimate off by 1.1-fold (0.03 log units), on the high side; low and high end bracket the measured number.
By their numbers in this assay, from the lowest: compounds 1, 4 and 2 (each within the scatter of the next).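

In this assay, going by these compounds alone, the 4-nitrophenyl group reads alike with the earlier compounds, with a 1.1-fold higher number from compound 1 to compound 4 (0.06 log units; within the scatter) and a 1.3-fold lower number from compound 2 to compound 4 (0.11 log units; within the scatter) on this aromatic carbon. Hydrogen, hydroxy and nitro at this spot on the phenyl ring therefore show no change beyond the scatter, so a second substituent now joins hydroxy in leaving the number in place. The step from compound 3 cannot be read, as compound 3 has no number. Still open, on these data alone, is whether an amine or a carboxylic acid on that carbon would move the value. Nothing on hand explains why these three compounds read alike.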